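Removal of the acyl group on the ring amine

A few compounds are considered here, and "the series" means these few. Any claim that something is new, unique, unknown or untested is made for them only; others in the source may bear on it.

Measured compounds and their numbers:
compound 1 `C=C(Br)C(=O)Nc1ccc(/C=C2\SC(=O)N(Cc3ccc(C)cc3)C2=O)cc1` — 8900 nM
compound 2 `C=C(Br)C(=O)Nc1ccc(/C=C2\SC(=O)N(CC)C2=O)cc1` — 1400 nM
compound 3 `C=C(Br)C(=O)Nc1ccc(/C=C2\SC(=O)N(Cc3ccc(C(F)(F)F)cc3)C2=O)cc1` — 13000 nM

In a functional assay on HeLa cells (Homo sapiens) for cytotoxicity, read by cell counting, with a stated time of 4 days (on this read-out lower numbers stand for stronger inhibition and higher numbers for weaker inhibition), compound 1 gives 8900 nM, the second highest of the three numbers. Its nearest neighbour is compound 3, a step of a 1.5-fold higher number from compound 1 to compound 3 (0.16 log units; within the scatter); its furthest is compound 2, a step of a 6.4-fold lower number from compound 1 to compound 2 (0.80 log units; beyond the scatter). The step of a 9.3-fold higher number from compound 2 to compound 3 (0.97 log units; beyond the scatter) completes the set.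

Compound 4 `Cc1ccc(CN2C(=O)S/C(=C\c3ccc(N)cc3)C2=O)cc1` differs from compound 1 by hydrogen in place of (1-bromoethenyl)carbonyl on a nitrogen on an aromatic ring.

All three measured steps concern the group on the saturated chain carbon bound to the amide-type nitrogen in the ring, or a substituent on the aromatic ring of that group. None touches the nitrogen on the aromatic ring where the change from compound 1 to compound 4 sits. For the measured compounds named here, no measured step therefore bears directly on this change, and the expectation rests on compound 1 alone.

With nothing in the series to scale the step, the estimate for compound 4 is set at a higher number than compound 1, a step of a 3.4-fold higher number from compound 1 to compound 4 (0.53 log units; beyond the scatter). The range is wide because compound 1 gives 8900 nM and nothing else anchors it. Compound 4 is expected to give about 30000 nM, between 6000 nM and 150000 nM.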

Compound 4, half-maximal inhibitory concentration: > 250000 nM
Compound 4 was reported as a limit; the forecaster's own chance of this, stated with the estimate: 30%; at least 8.3-fold (0.92 log units) between middle value and limit.
By their numbers in this assay, from the lowest: compound 2; then compounds 1 and 3 (each within the scatter of the next). At a limit, above all of these: compound 4.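

In this assay, the nitrogen on the aromatic ring proves far more sensitive than the group on the saturated chain carbon: hydrogen in place of (1-bromoethenyl)carbonyl gives an at least 28-fold higher number from compound 1 to compound 4 (1.44 log units; beyond the scatter), whereas the largest earlier step was a 9.3-fold higher number from compound 2 to compound 3 (0.97 log units; beyond the scatter). For the compounds shown here, with the 4-methylphenyl side of compound 1 held constant, the measurable cytotoxicity in this pair therefore goes with the presence of the (1-bromoethenyl)carbonyl group on that nitrogen, something the earlier compounds could not show because all of them carry it. Compound 4 is a limit, so the full size of this step remains unknown: the limit of > 250000 nM in this assay, at which 1 of the 4 values shown sits.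

The pair does not separate the contribution of the bromine from that of the rest of the group, and an acetyl or plain acryloyl group on the same nitrogen would test that directly. It also leaves open whether the free amine would have the same effect on the background of compound 2, the compound with the lowest number in this set.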